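Cytotoxicity notes on the shared-core series

A few compounds are considered here, and "the series" means these few. Any claim that something is new, unique, unknown or untested is made for them only; others in the source may bear on it.

Measured so far:
compound 1 `Cc1ccc(-c2nnc(N3CCN(C(=O)CN4CCN(c5ccc([N+](=O)[O-])cc5)CC4)CC3)nc2-c2ccc(C)cc2)cc1`: > 844000 nM
compound 2 `COc1ccc(-c2nnc(N3CCN(C(=O)CN4CCN(c5ccccc5)CC4)CC3)nc2-c2ccc(OC)cc2)cc1`: > 863000 nM
compound 3 `COc1ccccc1N1CCN(CC(=O)N2CCN(c3nnc(-c4ccc(Cl)cc4)c(-c4ccc(Cl)cc4)n3)CC2)CC1`: 405000 nM

For the measured compounds named here, in an ADME assay on NIH3T3 cells (Mus musculus) for cytotoxicity, read by MTT assay, with a stated time of 24 h (on this read-out higher numbers stand for weaker inhibition and lower numbers for stronger inhibition), compound 3 gives 405000 nM, the only number recorded among the three. For compound 1 the entry > 844000 nM is a limit of this assay, not a number (the limit of > 844000 nM in this assay, at which 1 of the 3 values shown sits). For compound 2 the entry > 863000 nM is likewise a limit (the limit of > 863000 nM in this assay, at which 1 of the 3 values shown sits). Going by the values given here, no step between measured compounds that differ in one place exists here, so nothing yet measures the effect of a single change. Compound 4 `O=C(CN1CCN(c2cccc(Cl)c2)CC1)N1CCN(c2nnc(-c3ccc(Cl)cc3)c(-c3ccc(Cl)cc3)n2)CC1` differs from compound 3 by 3-chlorophenyl in place of 2-methoxyphenyl on an amine nitrogen in a ring. Among the compounds with values here, with no comparable step to lean on, the expected step from compound 3 to compound 4 in this assay is a 1.2-fold lower number from compound 3 to compound 4 (0.06 log units; within the scatter), not beyond the scatter in either direction. Compound 4 is estimated at 350000 nM, with a range from 150000 nM to 900000 nM.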

Compound 4, half-maximal inhibitory concentration: > 803000 nM
Compound 4: a limit, no number; the forecaster's own chance of this, stated with the estimate: 30%; middle value at least 2.2-fold (0.36 log units) away from the limit.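

In this assay, for the compounds shown here, compound 4 gives > 803000 nM as a limit and not a number. 3-chlorophenyl in place of 2-methoxyphenyl on an amine nitrogen in a ring gives an at least 1.9-fold higher number from compound 3 to compound 4 (0.29 log units; that floor lies within the scatter) as the first reading of a single change. On these data alone, only a floor is fixed, so the true size of the step stays unknown. As far as these compounds go, whether 2-methoxyphenyl is distinctive at this position remains open, since compound 3 alone carries a number. Also open, from the compounds shown here alone, is what a carboxylic acid or a longer chain would give in that place.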